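Spiro-oxindole triazole series: aryl swaps at the assay limit

The source may report more compounds than this note shows. Statements on the series, on what has been measured and on what is new or still open speak of the compounds shown alone.

Measured so far:
compound 1 `CCOc1ccc(-n2nncc2CN2C(=O)C3(C(C#N)=C(N)Oc4c3c3nc5ccccc5nc3c3ccccc43)c3ccccc32)cc1` — in a functional assay on HepG2 cells (Homo sapiens) for antiproliferative activity, read by MTT assay, with a stated time of 48 h (on this read-out lower numbers stand for stronger inhibition and higher numbers for weaker inhibition), compound 1 gives > 50000 nM, a limit of the assay.
compound 2 `Cc1ccc(-n2nncc2CN2C(=O)C3(C(C#N)=C(N)Oc4c3c3nc5ccccc5nc3c3ccccc43)c3ccccc32)c(C)c1` — in this assay compound 2 gives > 50000 nM, a limit of the assay.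
compound 3 `Cc1ccc(Cl)cc1-n1nncc1CN1C(=O)C2(C(C#N)=C(N)Oc3c2c2nc4ccccc4nc2c2ccccc32)c2ccccc21` — in this assay compound 3 gives > 50000 nM, a limit of the assay.

Compound 3 stands where every measured member of the series stands: the limit of > 50000 nM in this assay, at which 3 of the 3 values shown sit. The three compounds differ only in the aryl group on the aromatic nitrogen, and the steps between them read a step that the two limits leave unreadable from compound 1 to compound 2, a step that the two limits leave unreadable from compound 1 to compound 3 and a step that the two limits leave unreadable from compound 2 to compound 3. No size and no direction can be taken from any of them.

Compound 4 `N#CC1=C(N)Oc2c(c3nc4ccccc4nc3c3ccccc23)C12C(=O)N(Cc1cnnn1-c1ccc(Cl)c(Cl)c1)c1ccccc12` makes the same kind of change at the same place: 3,4-dichlorophenyl in place of 5-chloro-2-methylphenyl on an aromatic nitrogen. Among the compounds with values here, all steps that bear on it are unreadable, and the sole evidence is the limit of > 50000 nM in this assay, at which 3 of the 3 values shown sit. The step from compound 3 to compound 4 is expected to be a number no higher from compound 3 to compound 4 (the limit leaves the size open), that is, nothing beyond the scatter, with a limit again the most probable outcome. Compound 4 is expected at 50000 nM, ranging from 20000 nM to 150000 nM.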

Compound 4, half-maximal inhibitory concentration: > 50000 nM
Compound 4: no number, only a limit; the forecaster's own chance of this, stated with the estimate: 80%; the middle value sits exactly at the limit.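

Within the data shown here, no step from compound 1, compound 2 or compound 3 to compound 4 can be read, since each value is a limit and not a number: the limit of > 50000 nM in this assay, at which 4 of the 4 values shown sit. The compounds shown leave open whether these aryl groups on the aromatic nitrogen differ at all in this assay, and by how much.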